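The source may hold more compounds than are shown below. What is called first, only, known or untested is meant among the compounds shown, and "the series" means these compounds.

Working notes on the series. In an ADME assay on cells (Hepatocyte, Rattus norvegicus, strain Wistar) for pharmacokinetics, read by LC-MS, with a stated time of 90 min, tested at 1 uM (on this read-out lower numbers stand for slow clearance and higher numbers for fast clearance), compound 1 (`COc1cc(C(=O)N2CC(C)OCC2C2CC(O)C2)cc2nc(N[C@H](C)c3cccc(Cl)c3)oc12`) gives 56.7 mL/min/kg and compound 2 (`COc1cc(C(=O)N2CC(C)OCC2CCO)cc2nc(NCc3cc(Cl)ccn3)oc12`) gives 20 mL/min/kg on the same read-out. Compound 2 therefore holds the lower of the two numbers, and its gap to compound 1 lies beyond the usual scatter. These two compounds differ in more than one place, so their gap isolates no single group. Compound 3 (`COc1cc(C(=O)N2CC(C)OCC2C2CC(O)C2)cc2nc(NCc3cc(Cl)ccn3)oc12`) departs from compound 2 by one change (3-hydroxycyclobutyl in place of 2-hydroxyethyl on a saturated ring carbon) in which 3-hydroxycyclobutyl takes the place of 2-hydroxyethyl on a saturated ring carbon. Among the measured compounds shown here, no measured pair shows this change alone. For the measured compounds named here, the only guide is compound 1, which also carries 3-hydroxycyclobutyl and stands at 56.7 mL/min/kg in this assay on a different side chain, so a modest rise is expected rather than a fall. The step expected is a 1.5-fold higher number from compound 2 to compound 3 (0.18 log units; within the scatter) upward and within the usual scatter, though a larger rise cannot be excluded. The estimated clearance of compound 3 is 30 mL/min/kg with 15 mL/min/kg to 55 mL/min/kg as the expected range.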

Compound 3, clearance: 45 mL/min/kg
The estimate for compound 3 lay 1.5-fold (0.18 log units) below the measured number; measured number inside the range.
By their numbers in this assay, from the lowest: compound 2; then compounds 3 and 1 (each within the scatter of the next).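

In this assay, the step at this saturated ring carbon, next to the ring nitrogen, can now be read on its own: 3-hydroxycyclobutyl in place of 2-hydroxyethyl gives a 2.3-fold higher number from compound 2 to compound 3 (0.35 log units; beyond the scatter), so the group here changes the clearance read-out by more than the scatter while the (4-chloropyridin-2-yl)methyl side chain stays the same. With 3-hydroxycyclobutyl held constant, (4-chloropyridin-2-yl)methyl in place of 1-(3-chlorophenyl)ethyl on a nitrogen on an aromatic ring gives a 1.3-fold lower number from compound 1 to compound 3 (0.10 log units; within the scatter), which lies within the scatter, so this pair does not separate the two side chains. No supporting data on either change are available to explain these results.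

It remains open whether the step seen with 3-hydroxycyclobutyl and 2-hydroxyethyl would recur with 1-(3-chlorophenyl)ethyl as the side chain, since only the 3-hydroxycyclobutyl form is shown with that group. As far as these compounds go, how an amine, a carboxylic acid or a longer hydroxyalkyl chain on the same saturated ring carbon would read in this assay also remains open.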